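The compounds below may be only part of what the source reports. "The series", "measured", "known", "first", "only" and "open" are said of these compounds alone.

Measured compounds in the series:

Compound 1 `C=C[C@@](C)(/C=C/c1ccc(Nc2ccc(OC)cc2)cc1)CCC=C(C)C`. In an ADME assay on BJ cells (Homo sapiens) for cytotoxicity, with a stated time of 72 h (on this read-out lower numbers stand for an effect already at smaller amounts and higher numbers for an effect only at larger amounts of compound), compound 1 gives > 36600 nM, which is a limit of the assay and not a number.
Compound 2 `C=C[C@@](C)(/C=C/c1ccc(Nc2ccc(OC)c(OC)c2)cc1)CCC=C(C)C`. In this assay compound 2 gives > 36600 nM, likewise a limit.
Compound 3 `C=C[C@@](C)(/C=C/c1ccc(Nc2c(F)cc(F)cc2F)cc1)CCC=C(C)C`. In this assay compound 3 gives > 36600 nM, also a limit.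

Compound 1 stands at the limit, as do the other two values (the limit of > 36600 nM in this assay, at which 3 of the 3 values shown sit). Both measured steps are therefore unreadable: a step that the two limits leave unreadable from compound 1 to compound 2 and a step that the two limits leave unreadable from compound 1 to compound 3, the one methoxy in place of hydrogen on an aromatic carbon, the other 2,4,6-trifluorophenyl in place of 4-methoxyphenyl on a nitrogen on an aromatic ring. Compound 4 `C=C[C@@](C)(/C=C/c1ccc(-c2ccc(Cl)cc2)cc1)CCC=C(C)C` differs from compound 1 as follows: 4-chlorophenyl in place of (4-methoxyphenyl)amino on an aromatic carbon. Neither measured step covers a change of this kind; both keep the nitrogen link to the shared core, which compound 4 loses. No size or direction can be read from them. Since every value sits at the limit (the limit of > 36600 nM in this assay, at which 3 of the 3 values shown sit), compound 4 is expected to sit there as well, giving an estimate of 40000 nM with a range from 15000 nM to 120000 nM. The expected step that the limit leaves unreadable from compound 1 to compound 4 is thus estimated as none beyond the scatter.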

Compound 4, half-maximal effective concentration: > 36600 nM
Compound 4 ended at the assay's limit (the forecaster's own chance of this, stated with the estimate: 75%); the middle value lies beyond the limit too.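

Compound 4, like compound 1, gives a limit and not a number in this assay, so the step between them cannot be read: the limit of > 36600 nM in this assay, at which 4 of the 4 values shown sit. The compounds shown leave open how far each lies beyond that limit and whether any change to the shared core gives a measurable value.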